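This account rests on a few compounds, and the source may have more. Where it says the series, first, only, none or still open, it means among the compounds named here.

Compound 1 `O=c1c2ccccc2c(Cc2ccc(Cl)cc2)nn1-c1ccc([N+](=O)[O-])cc1`: 29000 nM
Compound 2 `O=c1c2ccccc2c(Cc2ccc(Cl)cc2)nn1-c1ccc(Br)cc1`: > 30000 nM

In a functional assay on aorta with Alpha-1D adrenergic receptor (Rattus norvegicus) as the target (on this read-out higher numbers stand for an effect only at larger amounts of compound and lower numbers for an effect already at smaller amounts), compound 1 gives 29000 nM. For compound 2 only a limit is known, > 30000 nM, which is the limit of > 30000 nM in this assay, at which 1 of the 2 values shown sits. Among the compounds with values here, the single measured step, an at least 1.0-fold higher number from compound 1 to compound 2 (0.01 log units; that floor lies within the scatter), therefore shows no change beyond the scatter. Compound 3 `Cn1nc(Cc2ccc(Cl)cc2)c2ccccc2c1=O` is not yet measured; it differs from compound 2 by methyl in place of 4-bromophenyl on an aromatic nitrogen. Within the data shown here, no measured step bears on an exchange at the aromatic nitrogen, so the expectation rests only on the weak values of compound 1 and compound 2. Compound 3 is expected to give about 30000 nM, between 8000 nM and 100000 nM, an estimated step of a number no higher from compound 2 to compound 3 (the limit leaves the size open).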

Compound 3, half-maximal effective concentration: 430 nM
Compound 3: middle estimate off by 70-fold (1.84 log units), on the high side, and the stated range ends above it.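

The group on this aromatic nitrogen strongly affects the result in this assay, which the two earlier compounds could not show, as both carry a substituted phenyl there. Methyl in place of 4-bromophenyl gives an at least 69-fold lower number from compound 2 to compound 3 (1.84 log units; beyond the scatter), and methyl in place of 4-nitrophenyl gives a 67-fold lower number from compound 1 to compound 3 (1.83 log units; beyond the scatter). The first step is only a minimum, since compound 2 stands at a limit: the limit of > 30000 nM in this assay, at which 1 of the 3 values shown sits.

The compounds shown leave open how an ethyl group, a longer carbon chain or a chain ending in an amine on this nitrogen would read. They also leave open whether a plain phenyl would read like the two substituted ones.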